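A trifluoromethyl in place of a carboxamide

A few compounds are considered here, and "the series" means these few. Any claim that something is new, unique, unknown or untested is made for them only; others in the source may bear on it.

Of the compounds shown here, three have been measured in an assay for inhibition of Fatty-acid amide hydrolase 1 (Rattus norvegicus); on this read-out lower numbers stand for stronger inhibition and higher numbers for weaker inhibition. Compound 1 `O=C(O)c1ccc(-c2cnc(C(=O)CCc3ccc(-c4ccccc4)cc3)o2)cn1` gives 44 nM, compound 2 `O=C(O)c1cccc(-c2cnc(C(O)CCc3ccc(-c4ccccc4)cc3)o2)n1` gives 1100 nM, and compound 3 `NC(=O)c1cnc(C(=O)CCc2ccc(Oc3ccccc3)cc2)o1` gives 6.6 nM, the lowest of the three numbers and beyond the scatter from both others. Compound 4 `O=C(CCc1ccc(Oc2ccccc2)cc1)c1ncc(C(F)(F)F)o1` differs from compound 3 in one place: trifluoromethyl in place of carbamoyl on an aromatic carbon. Among the measured compounds shown here, no step between measured compounds shows what such a change does in this assay, so the expectation rests only on compound 3 and on its standing as the strongest inhibitor so far. The step from compound 3 to compound 4 is expected to be modest, toward weaker inhibition, or none beyond the scatter, giving a 2.3-fold higher number from compound 3 to compound 4 (0.36 log units; beyond the scatter). Compound 4 is therefore estimated at 15 nM, with a range from 4 nM to 60 nM.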

Compound 4, inhibition constant: 2 nM
Compound 4: middle estimate off by 7.5-fold (0.88 log units), on the high side; the measured number lies below the stated range.
By their numbers in this assay, from the lowest: compound 4; then compound 3; then compound 1; then compound 2.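

In this assay, trifluoromethyl in place of carbamoyl next to the ring oxygen gives a 3.3-fold lower number from compound 3 to compound 4 (0.52 log units; beyond the scatter) and so moves toward stronger inhibition. Strong inhibition at this position therefore does not depend on the carbamoyl hydrogen-bond donor or acceptor, since trifluoromethyl has neither. No supporting measurement explains why the number falls.

Going by these compounds, it remains open how a carboxylic acid, a nitrile or a methyl at this position would compare. On these data alone, it is also open whether the same change would give a similar step on the core of compound 1.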